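This account rests on a few compounds, and the source may have more. Where it says the series, first, only, none or still open, it means among the compounds named here.

For the measured compounds named here, compound 3 `COCc1cccc2[nH]c(-c3n[nH]c4ncc(-c5ccncc5)cc34)nc12` gives 62 nM in a functional assay on HCT-116 cells (Homo sapiens) for antiproliferative activity (on this read-out higher numbers stand for weaker inhibition and lower numbers for stronger inhibition), which places it second highest of the three numbers measured so far. Its nearest neighbour is compound 2 `COCc1cccc2[nH]c(-c3n[nH]c4ncc(-c5cccnc5)cc34)nc12`, which gives 19 nM; the furthest is compound 1 `c1ccc2c(-c3cnc4[nH]nc(-c5nc6ccccc6[nH]5)c4c3)cncc2c1`, which gives 550 nM. Compound 4 `COCc1cccc2[nH]c(-c3n[nH]c4ncc(-c5cncnc5)cc34)nc12` differs from compound 3 in a single place: pyrimidin-5-yl in place of pyridin-4-yl on an aromatic carbon. Going by the values given here, the only measured step that concerns this same attached ring is a 3.3-fold higher number from compound 2 to compound 3 (0.51 log units; beyond the scatter), a modest change. A step of comparable size is therefore expected from this further change of the attached ring, with the direction uncertain, and compound 4 is expected to give about 40 nM in this assay, within a range from 15 nM to 110 nM. That estimate means an expected step of a 1.6-fold lower number from compound 3 to compound 4 (0.19 log units; within the scatter).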

Compound 4, half-maximal inhibitory concentration: 330 nM
Estimate against measurement, compound 4: 8.3-fold (0.92 log units) below; measured number outside the range, above it.
By their numbers in this assay, from the lowest: compound 2; then compound 3; then compounds 4 and 1 (each within the scatter of the next).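

Adding a second ring nitrogen at this position is clearly not neutral: pyrimidin-5-yl gives a 5.3-fold higher number from compound 3 to compound 4 (0.73 log units; beyond the scatter) and a 17-fold higher number from compound 2 to compound 4 (1.24 log units; beyond the scatter), the second step being large. Among compounds 2, 3 and 4, both rings with one nitrogen therefore give stronger inhibition than the ring with two. No evidence here explains this loss. Still open, from the compounds shown here alone, is how a plain phenyl ring, with no ring nitrogen, would compare at this position, and whether an amine on the pyridin-3-yl ring of compound 2 would keep its low number.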